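Bromoacrylamide Capping of the Aniline in the Thiadiazole Series

A few compounds are considered here, and "the series" means these few. Any claim that something is new, unique, unknown or untested is made for them only; others in the source may bear on it.

Measured so far:
compound 1, `C=C(Br)C(=O)Nc1cccc(-c2cn3nc(Cc4ccccc4)sc3n2)c1`: 3000 nM
compound 2, `COc1ccc(-c2nn3cc(-c4cccc(N)c4)nc3s2)cc1OC`: 16000 nM

In a functional assay on L1210 cells (Mus musculus) for inhibition, read by cell counting, with a stated time of 2 days (on this read-out lower numbers stand for stronger inhibition and higher numbers for weaker inhibition), compound 2 gives 16000 nM, the higher of the two numbers; compound 1 gives 3000 nM, a gap beyond the scatter. Compound 3, `C=C(Br)C(=O)Nc1cccc(-c2cn3nc(-c4ccc(OC)c(OC)c4)sc3n2)c1`, differs from compound 2 by (1-bromoethenyl)carbonyl in place of hydrogen on a nitrogen on an aromatic ring, in words (1-bromoethenyl)carbonyl in place of hydrogen on a nitrogen on an aromatic ring. Going by the values given here, no measured pair isolates this change. Compound 1, which carries the same capped aniline, gives 3000 nM, so a step toward lower numbers beyond the scatter is expected, a 5.3-fold lower number from compound 2 to compound 3 (0.73 log units; beyond the scatter). Compound 3 is estimated at 3000 nM, range 800 nM to 10000 nM.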

Compound 3, half-maximal inhibitory concentration: 42 nM
Beside the measured number, compound 3's estimate is 71-fold (1.85 log units) above it, outside the stated range (below it).
By their numbers in this assay, from the lowest: compound 3; then compound 1; then compound 2.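

In this assay, going by these compounds alone, the (1-bromoethenyl)carbonyl on the nitrogen gives a 380-fold lower number from compound 2 to compound 3 (2.58 log units; beyond the scatter) as a change in one place, a reading that no earlier pair offered. With that group held constant, 3,4-dimethoxyphenyl in place of benzyl on an aromatic carbon gives a 71-fold lower number from compound 1 to compound 3 (1.85 log units; beyond the scatter) in the same read-out, so the number for compound 3 depends strongly on both places.

Open, going by these compounds, is whether the bromine is needed for the first step: a plain acryloyl, a chloroacryloyl or an acetyl on the same nitrogen would test this. No measurement shown bears on the cause of either step.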